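Fluoro for trifluoromethyl on the sulfonyl aryl: expected step

The compounds below may be only part of what the source reports. "The series", "measured", "known", "first", "only" and "open" are said of these compounds alone.

Measured in a functional assay on HepG2 cells (Homo sapiens) for cytotoxicity, read by MTT assay, with a stated time of 24 h; a lower number here means a stronger inhibitor, a higher number a weaker inhibitor:
compound 1, `O=C1/C(=C/c2ccccc2F)CN(S(=O)(=O)c2ccc(C(F)(F)F)cc2)C/C1=C\c1ccccc1F`, 4900 nM
compound 2, `O=C1/C(=C/c2ccccc2F)CN(S(=O)(=O)c2ccc(F)cc2)C/C1=C\c1ccccc1F`, 8000 nM
compound 3, `O=C1/C(=C/c2cccc(F)c2)CN(S(=O)(=O)c2ccc(C(F)(F)F)cc2)C/C1=C\c1cccc(F)c1`, 2400 nM

Compound 1 and compound 2 differ by fluoro in place of trifluoromethyl on an aromatic carbon; this gave a 1.6-fold higher number from compound 1 to compound 2 (0.21 log units; within the scatter). Compound 3 carries a different core; the difference between the two cores is not broken down here. Compound 3 stands lowest of the three values, with compound 1 nearest and compound 2 furthest. Compound 4, `O=C1/C(=C/c2cccc(F)c2)CN(S(=O)(=O)c2ccc(F)cc2)C/C1=C\c1cccc(F)c1`, is not yet measured; it differs from compound 3 by fluoro in place of trifluoromethyl on an aromatic carbon, the same change made at the same place as from compound 1 to compound 2. For compound 4 in this assay a step of about the same size is expected, a 1.6-fold higher number from compound 3 to compound 4 (0.20 log units; within the scatter), because the earlier change gave a 1.6-fold higher number from compound 1 to compound 2 (0.21 log units; within the scatter). The estimate for compound 4 is 3800 nM, expected between 2000 nM and 7500 nM.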

Compound 4, half-maximal inhibitory concentration: 5000 nM
Compound 4: the middle estimate sits 1.3-fold (0.12 log units) below what was measured, within the range that was stated.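

In this assay, the new step is a 2.1-fold higher number from compound 3 to compound 4 (0.32 log units; beyond the scatter), so fluoro in place of trifluoromethyl again gives a higher number on the second core. The sizes of the step on the two cores do not differ: the same change on two cores in this assay, a 1.6-fold higher number (0.21 log units; within the scatter) from compound 1 to compound 2 and a 2.1-fold higher number (0.32 log units; beyond the scatter) from compound 3 to compound 4, 1.3-fold (0.11 log units) apart, within the scatter of two such steps. This supports carrying the change between these two cores, but it rests on two pairs, one of them within the scatter, and shows nothing about other cores or other assays.

Going by these compounds, only trifluoromethyl and fluoro appear at this place, so it stays open whether a nitrile, a methoxy group or an amine there would fit the same picture. The effect of the difference between the two cores also remains unresolved.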